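The compounds below may be only part of what the source reports. "The series", "measured", "known", "first", "only" and "open" are said of these compounds alone.

Measured so far:
- compound 1, `COc1cc(N(CC2CC2)c2ccc(Cl)c(Cl)c2)cnc1C(=O)[C@H]1C[C@@H]1C(=O)O`, in an assay on isolated protein for inhibition of leukotriene C4 synthase (Homo sapiens), read by LC-MS, with stated times of 45 min and 20 min; on this read-out lower numbers stand for stronger inhibition and higher numbers for weaker inhibition: 27.7 nM
- compound 2, `COc1cc(N(CC2CC2)c2ccccc2)cnc1C(=O)[C@H]1C[C@@H]1C(=O)O`, in this assay: 1640 nM

For the measured compounds named here, compound 2 gives the higher of the two numbers; the only measured step leading to it, a 59-fold higher number from compound 1 to compound 2 (1.77 log units; beyond the scatter), is large and runs against compound 2.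

The next compound, compound 3, `COc1cc(N(CC2CC2)c2cccc(C(F)(F)F)c2)cnc1C(=O)[C@H]1C[C@@H]1C(=O)O`, differs from compound 2 in one place: trifluoromethyl in place of hydrogen on an aromatic carbon. Read one bond further out, the aryl on the nitrogen goes from phenyl to 3-(trifluoromethyl)phenyl, on an aromatic carbon meta to a large group.

Going by the values given here, the single step that bears on this change is a 59-fold higher number from compound 1 to compound 2 (1.77 log units; beyond the scatter): moving from a doubly substituted aryl to the bare phenyl raises the number far beyond the scatter. Compound 3 puts a single substituent back onto that ring. Among the compounds with values here, the expectation is therefore a lower number for compound 3 than for compound 2, but a step smaller than the one seen between compound 1 and compound 2, since only one group returns; the expected step is an 11-fold lower number from compound 2 to compound 3 (1.04 log units; beyond the scatter). Within the data shown here, no measured compound carries a trifluoromethyl, so the estimate is loosely held. For compound 3 the expected value in this assay is 150 nM, within a range of 40 nM to 600 nM.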

Compound 3, half-maximal inhibitory concentration: 52.4 nM
Estimate against measurement, compound 3: 2.9-fold (0.46 log units) above, and the stated range covers the measured number.
By their numbers in this assay, from the lowest: compounds 1 and 3 (each within the scatter of the next); then compound 2.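

In this assay, one trifluoromethyl on an aromatic carbon, meta to a large group, is enough to undo most of the loss seen with the bare phenyl, giving a 31-fold lower number from compound 2 to compound 3 (1.50 log units; beyond the scatter). The second comparison gives a 1.9-fold higher number from compound 1 to compound 3 (0.28 log units; within the scatter), so 3-(trifluoromethyl)phenyl and 3,4-dichlorophenyl cannot be told apart on this read-out, and two substituents on the ring are not needed for a number in this range. Nothing available speaks to the reason for either step.

As far as these compounds go, it remains open whether this recovery is particular to trifluoromethyl or would also come from a single chlorine, a methyl or a nitrile on the same aromatic carbon, and whether trifluoromethyl would do the same on another carbon of the ring. From the compounds shown here alone, all three compounds share the rest of the core, so it is also open whether a step of this size would carry over to a compound with an amide in place of the carboxylic acid.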